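Swapping phenyl for iodo on a shared nucleoside core

This account rests on a few compounds, and the source may have more. Where it says the series, first, only, none or still open, it means among the compounds named here.

Of the compounds shown here, three built on one sugar-bearing core have been measured. Compound 1 `Cc1ncnc2c1c(I)cn2[C@@H]1O[C@H](CO)[C@@H](O)[C@H]1O` carries iodo together with a methyl group, and in a functional assay on HL-60 cells (Homo sapiens) for antiproliferative activity, read by XTT assay, with a stated time of 72 h (on this read-out lower numbers stand for stronger inhibition and higher numbers for weaker inhibition), compound 1 gives 2650 nM. Compound 2 `CSc1ncnc2c1c(-c1ccccc1)cn2[C@@H]1O[C@H](CO)[C@@H](O)[C@H]1O` carries phenyl together with methylsulfanyl. In this assay compound 2 reaches only > 20000 nM, which is a limit of the assay and not a number. Compound 3 `COc1ncnc2c1c(-c1ccccc1)cn2[C@@H]1O[C@H](CO)[C@@H](O)[C@H]1O` carries phenyl together with methoxy. In this assay compound 3 likewise reaches only > 20000 nM, again a limit rather than a number. The step that the two limits leave unreadable from compound 2 to compound 3 therefore cannot be sized, and compound 3 stands at the limit among the numbers shown, as the limit of > 20000 nM in this assay, at which 2 of the 3 values shown sit, records.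

Compound 4 `COc1ncnc2c1c(I)cn2[C@@H]1O[C@H](CO)[C@@H](O)[C@H]1O` is the compound still to be measured: iodo in place of phenyl on an aromatic carbon. Within the data shown here, no measured step covers this exact exchange. Among the measured compounds shown here, the only guide is compound 1, which also carries iodo and gives 2650 nM. The two phenyl-bearing compounds, in contrast, sit at the limit. For the measured compounds named here, compound 4 also carries methoxy rather than methyl, and no step shows the weight of that exchange. For compound 4 the estimated value in this assay is 5000 nM, within a range from 1200 nM to 20000 nM. This is expected to amount to a step of an at least 4.0-fold lower number from compound 3 to compound 4 (0.60 log units; beyond the scatter), though the limit on compound 3 leaves its true size uncertain.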

Compound 4, half-maximal inhibitory concentration: 2300 nM
Compound 4: middle estimate off by 2.2-fold (0.34 log units), on the high side, within the range that was stated.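

On the aromatic carbon of the five-membered ring, two ring bonds from the ring nitrogen, iodo in place of phenyl gives an at least 8.6-fold lower number from compound 3 to compound 4 (0.93 log units; beyond the scatter) in this assay and so shows that the group at this carbon matters on this read-out. The true size of that step remains uncertain, since the value for compound 3 is a limit of the assay and not a number: the limit of > 20000 nM in this assay, at which 2 of the 4 values shown sit. The step between the two phenyl compounds cannot be read, whereas the iodo pair can, and methoxy in place of methyl on an aromatic carbon gives a 1.2-fold lower number from compound 1 to compound 4 (0.06 log units; within the scatter) with iodo in place, so this exchange leaves the read-out within the usual scatter.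

With only iodo and phenyl shown at this carbon, it remains open whether bromo, ethynyl or an amine there would match compound 4 or fall to the limit seen with phenyl. As far as these compounds go, it is also open what an amine or a longer chain such as butoxy would do on the carbon that carries methoxy in compound 4.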